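Amine exchange at the chain carbon: compound 3 to compound 4

The source may hold more compounds than are shown below. What is called first, only, known or untested is meant among the compounds shown, and "the series" means these compounds.

- compound 1 `CC(=O)OC/C1=C/C[C@](C)(CCC=C(C)C)/C=C/[C@@H](OC(=O)C=C(C)C)[C@](C)(O)/C=C/C1=O`: 2950 nM
- compound 2 `CCN(CC)C/C1=C/C[C@](C)(CCC=C(C)C)/C=C/[C@@H](OC(=O)C=C(C)C)[C@](C)(O)/C=C/C1=O`: 570 nM
- compound 3 `CC(C)=CCC[C@]1(C)/C=C/[C@@H](OC(=O)C=C(C)C)[C@](C)(O)/C=C/C(=O)/C(CN2CCCC2)=C\C1`: 140 nM
- compound 4 `CC(C)=CCC[C@]1(C)/C=C/[C@@H](OC(=O)C=C(C)C)[C@](C)(O)/C=C/C(=O)/C(CN2CCN(C)CC2)=C\C1`: not yet measured

In a functional assay on SMMC-7721 cells (Homo sapiens) for antiproliferative activity, read by MTT assay, with a stated time of 48 h (on this read-out higher numbers stand for weaker inhibition and lower numbers for stronger inhibition), compound 3 gives the lowest number of the three measured compounds, at 140 nM. The next change is 4-methylpiperazin-1-yl in place of pyrrolidin-1-yl on a saturated chain carbon bound to a double-bonded ring carbon.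

All three measured steps fall at this place. Two replace acetoxy: a 5.2-fold lower number from compound 1 to compound 2 (0.71 log units; beyond the scatter) and a 21-fold lower number from compound 1 to compound 3 (1.32 log units; beyond the scatter). For the measured compounds named here, the third, a 4.1-fold lower number from compound 2 to compound 3 (0.61 log units; beyond the scatter), is the nearest precedent, since one amino group replaces another there. It shows that such an exchange can move the number beyond the scatter. Going by the values given here, no measured compound carries 4-methylpiperazin-1-yl, so the direction is uncertain. Since compound 3 already holds the lowest value, a modest step to a higher number in this assay is expected. The expected step is a 2.9-fold higher number from compound 3 to compound 4 (0.46 log units; beyond the scatter). The estimate for compound 4 is 400 nM, with an expected range of 130 nM to 1300 nM.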

Compound 4, half-maximal inhibitory concentration: 2940 nM
Beside the measured number, compound 4's estimate is 7.4-fold (0.87 log units) below it; measured number outside the range, above it.
By their numbers in this assay, from the lowest: compound 3; then compound 2; then compounds 4 and 1 (each within the scatter of the next).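

In this assay an amine at this place does not by itself lower the number: a 1.0-fold lower number from compound 1 to compound 4 (0.00 log units; within the scatter) leaves 4-methylpiperazin-1-yl indistinguishable from acetoxy, unlike diethylamino and pyrrolidin-1-yl. Exchanging one amine for another can also be a large step, as a 21-fold higher number from compound 3 to compound 4 (1.32 log units; beyond the scatter) shows for a pair that differs only in this group. Against diethylamino the step is smaller but still clear, and a 5.2-fold higher number from compound 2 to compound 4 (0.71 log units; beyond the scatter) puts 4-methylpiperazin-1-yl higher than both other amines.

On these data alone, whether the six-membered ring or the second ring nitrogen carries the step remains open, and piperidin-1-yl and morpholin-4-yl at the same place would separate the two. No measurement bearing on the cause of these steps is available.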